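A sulfur-for-oxygen change at the ring nitrogen

The source may report more compounds than this note shows. Statements on the series, on what has been measured and on what is new or still open speak of the compounds shown alone.

Measured in an ADME assay on HEK-293T cells (Homo sapiens) for cytotoxicity, read by CCK-8 assay, with a stated time of 48 h; on this read-out lower numbers stand for stronger inhibition and higher numbers for weaker inhibition
Compound 1 `COc1ccc(Oc2ccc([N+](=O)[O-])cc2-c2ccsc2S(=O)(=O)N2CCN(C(=S)Nc3ccc(Cl)cc3)CC2)cc1OC` gives > 50000 nM
Compound 2 `COc1ccc(Oc2ccc([N+](=O)[O-])cc2-c2ccsc2S(=O)(=O)N2CCN(C(=S)Nc3ccc([N+](=O)[O-])cc3)CC2)cc1OC` gives > 50000 nM

Compound 2 stands at > 50000 nM as a limit of the assay and not as a number. Compound 1 also reports only a limit, so neither compound gives a measured value, as the limit of > 50000 nM in this assay, at which 2 of the 2 values shown sit, shows.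

Compound 3 `COc1ccc(Oc2ccc([N+](=O)[O-])cc2-c2ccsc2S(=O)(=O)N2CCN(C(=O)Nc3ccc([N+](=O)[O-])cc3)CC2)cc1OC` keeps the core of compound 2 and changes one group (a group of 12 heavy atoms (7 carbon, 2 nitrogen, 3 oxygen; one six-membered aromatic ring of carbon only) in place of a group of 12 heavy atoms (7 carbon, 2 nitrogen, 2 oxygen, 1 sulfur; one six-membered aromatic ring of carbon only), on an amine nitrogen in a ring). Going by the values given here, the only measured step (a step that the two limits leave unreadable from compound 1 to compound 2) lies at another place in the molecule and has no readable size, so it offers neither a size nor a direction to carry over. No step beyond the usual scatter is therefore expected in this assay, and the estimated step is a step that the limit leaves unreadable from compound 2 to compound 3 as a rough figure. Compound 3 is estimated at 60000 nM with an expected range from 25000 nM to 150000 nM and will most likely report a limit again.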

Compound 3, half-maximal inhibitory concentration: > 20000 nM
Compound 3 ended at the assay's limit; the forecaster's own chance of this, stated with the estimate: 80%; the middle value does not contradict the limit.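

In this assay compound 3 gives > 20000 nM, a limit of the assay and not a number. Compound 1 and compound 2 also report only limits, so no step among these compounds can be read. The compounds shown leave open what real value any of them has, and so whether the (4-nitrophenyl)carbamoyl group changes the read-out at all.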